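Two measured compounds and a chlorophenyl swap

The source may hold more compounds than are shown below. What is called first, only, known or untested is meant among the compounds shown, and "the series" means these compounds.

Compound 1 `CN1C/C(=C\c2cccc([N+](=O)[O-])c2)C(=O)/C(=C/c2ccccc2F)C1` gives 2340 nM
Compound 2 `COc1cc(/C=C2\CN(C)C/C(=C\c3ccc(C#N)cc3)C2=O)cc(OC)c1` gives 3420 nM

In a functional assay on HeLa cells (Homo sapiens) for cytotoxicity, read by MTT assay, with a stated time of 24 h (on this read-out lower numbers stand for stronger inhibition and higher numbers for weaker inhibition), compound 1 (2340 nM) and compound 2 (3420 nM) lie within the usual scatter of each other, so compound 1 stands level with compound 2. Among the compounds with values here, this closeness is the only guide available here. Compound 3 `CN1C/C(=C\c2ccc(Cl)cc2)C(=O)/C(=C/c2cccc([N+](=O)[O-])c2)C1` carries 4-chlorophenyl in place of 2-fluorophenyl on a double-bonded chain carbon bound to a double-bonded ring carbon. The expected step of a 1.1-fold higher number from compound 1 to compound 3 (0.05 log units; within the scatter) in this assay stays within the scatter, with no firm direction. The expected value of compound 3 is 2600 nM with 1000 nM to 6500 nM as its estimated range.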

Compound 3, half-maximal inhibitory concentration: > 20000 nM
Compound 3 ended at the assay's limit; the forecaster's own chance of this, stated with the estimate: 3%; middle value at least 7.6-fold (0.88 log units) away from the limit.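

In this assay compound 3 gives > 20000 nM, which is a limit of the assay and not a number. Putting 4-chlorophenyl in place of 2-fluorophenyl on a double-bonded chain carbon bound to a double-bonded ring carbon brings an at least 8.5-fold higher number from compound 1 to compound 3 (0.93 log units; beyond the scatter). This place on the shared core is therefore sensitive to which substituted phenyl it carries, something the level values of the first two compounds could not reveal.

Still open, going by these compounds, is whether the chlorine or where it sits on the ring matters more, which a 2-chlorophenyl or 4-fluorophenyl group here would help to separate. On these data alone, how an amine or a carboxylic acid on that ring would behave also remains open.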